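The compounds below may be only part of what the source reports. "The series", "measured", "known", "first", "only" and "open" are said of these compounds alone.

In an ADME assay on MT4 cells (Homo sapiens) for cytotoxicity, read by MTT assay, with a stated time of 4 days (a lower number here means that less compound is tolerated, a higher number that more compound is tolerated), compound 3 `O=C(c1cc(F)cc(F)c1)c1cc(Cl)ccc1OCCn1ccc(=O)[nH]c1=O` gives > 307000 nM, which is a limit and not a number. Compound 1 `O=C(c1cc(Br)cc(Br)c1)c1cc(Cl)ccc1OCCn1ccc(=O)[nH]c1=O` also gives only a limit, > 236000 nM. Compound 2 `O=C(c1ccccc1)c1cc(Cl)ccc1OCCn1ccc(=O)[nH]c1=O` likewise gives only a limit, > 337000 nM. Compound 3 therefore has no measured number, and neither does either of the other two compounds.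

Compound 4 `Cc1cccc(C(=O)c2cc(Cl)ccc2OCCn2ccc(=O)[nH]c2=O)c1` carries 3-methylphenyl in place of 3,5-difluorophenyl on a carbonyl carbon.

Three measured changes at this same place bear on the new one: a step that the two limits leave unreadable from compound 1 to compound 2, a step that the two limits leave unreadable from compound 1 to compound 3 and a step that the two limits leave unreadable from compound 2 to compound 3. None of them has a size that can be read, and none gives a sign of any change in this assay. No step beyond the scatter is expected, in either direction, and the expected change is a step that the limit leaves unreadable from compound 3 to compound 4. Compound 4 is also expected to be reported as a limit rather than a number.

Compound 4 is estimated at 320000 nM, with an expected range from 150000 nM to 400000 nM.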

Compound 4, half-maximal cytotoxic concentration: > 325000 nM
Compound 4 ended at the assay's limit; the forecaster's own chance of this, stated with the estimate: 85%; middle value at least 1.0-fold (0.00 log units) from the limit.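

Among these compounds, compound 4, like compound 1, compound 2 and compound 3, is reported in this assay only as a limit, so no step between any of them can be read. The compounds shown leave open at what concentration any of the four becomes cytotoxic, and whether the groups on the carbonyl carbon differ in this respect at all.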